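This account rests on a few compounds, and the source may have more. Where it says the series, first, only, none or still open, it means among the compounds named here.

Three compounds share one core and differ only in the groups hung on it. Compound 1 `COc1ccc(-c2cc(/C=C/C(=O)c3ccc(N)cc3)[nH]n2)cc1` carries one methoxy on its outer ring; in a functional assay on OVCAR-8 cells (Homo sapiens) for inhibition, read by sulforhodamine B assay, with a stated time of 48 h (on this read-out lower numbers stand for higher toxicity in this test and higher numbers for lower toxicity in this test), compound 1 reaches only the assay limit of > 100000 nM. Within the data shown here, compound 2 `COc1cc(-c2cc(/C=C/C(=O)c3ccc(N)cc3)[nH]n2)cc(OC)c1OC`, with three methoxy groups on that ring, gives 34900 nM in this assay, the only real number among the three. Compound 3 `COc1cc(-c2cc(/C=C/C(=O)c3ccc(F)c(F)c3)[nH]n2)cc(OC)c1OC` also stops at the limit of > 100000 nM. The step of an at least 2.8-fold higher number from compound 2 to compound 3 (0.45 log units; beyond the scatter) alters the other end of the molecule and so does not bear on compound 4 `COc1ccc(-c2cc(/C=C/C(=O)c3ccc(N)cc3)[nH]n2)cc1OC`, whose change is hydrogen in place of methoxy on an aromatic carbon. Among the measured compounds shown here, no measured step matches this change directly. Compound 1, at its limit of > 100000 nM, has fewer methoxy groups. Compound 2 gives 34900 nM. Compound 4 is therefore expected near 70000 nM (range 25000 nM to 200000 nM), a step of a 2.0-fold higher number from compound 2 to compound 4 (0.30 log units; within the scatter).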

Compound 4, concentration lethal to 50% of the cells: 39000 nM
Compound 4: middle estimate off by 1.8-fold (0.25 log units), on the high side; the range from low to high includes it.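

In this assay, hydrogen in place of methoxy gives a 1.1-fold higher number from compound 2 to compound 4 (0.05 log units; within the scatter), so losing this methoxy from the ring of compound 2 leaves the number within the scatter. The same kind of exchange in reverse, methoxy in place of hydrogen, gives an at least 2.5-fold lower number from compound 1 to compound 4 (0.40 log units; beyond the scatter), so a second methoxy matters while a third adds nothing measurable. That step gives only a bound, since compound 1 sits at a limit: the limit of > 100000 nM in this assay, at which 2 of the 4 values shown sit.

Going by these compounds, whether a hydroxyl or a chlorine on this carbon would read like hydrogen or methoxy stays open. So does whether removing this methoxy would matter with the 3,4-difluorophenyl end of compound 3.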